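The source may report more compounds than this note shows. Statements on the series, on what has been measured and on what is new or still open speak of the compounds shown alone.

Compound 1 `Cc1cc(C(=O)O)nn1Cc1cc(Br)ccc1OCc1ccc(F)cc1` and compound 2 `Cc1cc(C(=O)O)nn1Cc1cc(Br)ccc1OCc1cccc(Br)c1` share one core and differ only in the ring carried on a saturated chain carbon bound to an oxygen on an aromatic ring. In a functional assay on CHO-K1 cells for antagonist activity at prostaglandin E2 receptor EP1 subtype (Homo sapiens), read by FLIPR (on this read-out higher numbers stand for weaker inhibition and lower numbers for stronger inhibition), compound 1 gives 11.8 nM. In this assay compound 2 gives 129 nM, the higher of the two numbers. For the measured compounds named here, the only measured step is an 11-fold higher number from compound 1 to compound 2 (1.04 log units; beyond the scatter). Compound 3 `Cc1cccc(COc2ccc(Br)cc2Cn2nc(C(=O)O)cc2C)c1` keeps that ring but carries methyl in place of bromo on an aromatic carbon. Going by the values given here, no measured step swaps bromo for methyl on this ring, and the one step that changed this ring was large, so a step of some size in either direction is plausible. Compound 3 is expected near 90 nM, between 25 nM and 320 nM. That estimate means an expected 1.4-fold lower number from compound 2 to compound 3 (0.16 log units; within the scatter).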

Compound 3, inhibition constant: 525 nM
Estimate against measurement, compound 3: 5.8-fold (0.77 log units) below; measured number outside the range, above it.
By their numbers in this assay, from the lowest: compound 1; then compound 2; then compound 3.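

With bromo and methyl each counted as one heavy atom, this place on the ring still separates them: in this assay methyl in place of bromo gives a 4.1-fold higher number from compound 2 to compound 3 (0.61 log units; beyond the scatter) and so moves the number further from that of the 4-fluorophenyl compound. Changing the whole ring gives a 44-fold higher number from compound 1 to compound 3 (1.65 log units; beyond the scatter) and shows that neither 3-substituted ring shown here matches 4-fluorophenyl. No evidence is available to explain this order.

As far as these compounds go, whether chloro or methoxy at this place would give a lower number than bromo remains open. So does how a 4-methylphenyl ring would compare with the 4-fluorophenyl ring of compound 1.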